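Swapping the benzyl group on the amine of compound 2

A few compounds are considered here, and "the series" means these few. Any claim that something is new, unique, unknown or untested is made for them only; others in the source may bear on it.

Compound 2 `COc1ccc(F)cc1CNCCCNc1ccnc2cc(Cc3ccc(F)cc3Cl)ccc12` stands highest of the two numbers in a physicochemical assay for acid dissociation, giving 9.47; its nearest neighbour, compound 1 `COc1ccc(F)cc1CNCCCNc1ccnc2cc(Oc3ccc(F)cc3)ccc12`, gives 9.28, a difference a number 0.19 log units higher from compound 1 to compound 2 (within the scatter). Compound 3 `COc1cccc(CNCCCNc2ccnc3cc(Cc4ccc(F)cc4Cl)ccc23)c1O` differs from compound 2 at the other end of the molecule: 2-hydroxy-3-methoxyphenyl in place of 5-fluoro-2-methoxyphenyl on a saturated chain carbon bound to an amine nitrogen. For the measured compounds named here, the one measured step concerns the far aromatic carbon, not the amine-side benzyl group, so it gives no direct guide. A step of a number 0.07 log units lower from compound 2 to compound 3 (within the scatter) is expected, within the scatter, and compound 3 is estimated at 9.4 with a range of 8.8 to 10.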

Compound 3, acid dissociation constant: 9.47
Compound 3: the middle estimate sits 0.07 log units below what was measured, within the range that was stated.
By their numbers in this assay, from the lowest: compounds 1, 2 and 3 (each within the scatter of the next).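

In this assay, 2-hydroxy-3-methoxyphenyl in place of 5-fluoro-2-methoxyphenyl brings no change at the digits printed from compound 2 to compound 3 (within the scatter). For the compounds shown here, this is the only reading at this end of the molecule, and here, exchanging a fluorine and a methoxy arrangement for a hydroxy-bearing ring that adds a hydrogen-bond donor leaves the number where it stood. Nothing measured here offers an explanation for this result. Still open, going by these compounds, is whether a more different group on this carbon, such as an amine or a carboxylic acid on the ring, would move the number beyond the scatter.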